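Aryl variation on the saturated ring carbon of the pyrazoline series

A few compounds are considered here, and "the series" means these few. Any claim that something is new, unique, unknown or untested is made for them only; others in the source may bear on it.

Compound 1 `CC(=O)N1N=C(c2ccc(OCc3cn(Cc4ccc([N+](=O)[O-])cc4)nn3)cc2)CC1c1ccccc1` is the reference point. In a functional assay on THP-1 cells (Homo sapiens) for inhibition, read by sulforhodamine B assay, tested at 100 uM (a higher number here means more inhibition of growth at the concentration tested, a lower number less inhibition of growth), compound 1 gives 22%, the higher of the two numbers available. Compound 2 `COc1cc(C2CC(c3ccccc3)=NN2C(C)=O)ccc1OCc1cn(Cc2ccc([N+](=O)[O-])cc2)nn1` differs at more than one place and gives 10% in this assay; the two values lie apart by more than the usual scatter, nothing further can be drawn from the pair.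

Compound 3 `COc1ccc(C2CC(c3ccc(OCc4cn(Cc5ccc([N+](=O)[O-])cc5)nn4)cc3)=NN2C(C)=O)cc1OC` carries 3,4-dimethoxyphenyl in place of phenyl on a saturated ring carbon. Within the data shown here, no measured pair isolates this change, so the expectation rests on compound 1 alone; the one other compound with a methoxy-bearing aryl, compound 2, gave 10%, which points weakly downward but is not a matched comparison. A modest step, downward or none beyond the scatter, is expected from compound 1 to compound 3, namely a number 6 percentage points lower from compound 1 to compound 3 (within the scatter). Compound 3 is therefore estimated at 16% in this assay, with a range from 4% to 30%.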

Compound 3, percent growth inhibition at one concentration: 9%
For compound 3 the middle estimate is 7 percentage points above the measured one, and the stated range covers the measured number.
By their numbers in this assay, from the lowest: compounds 3 and 2 (each within the scatter of the next); then compound 1.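

Among these compounds, the exchange of phenyl for 3,4-dimethoxyphenyl on a saturated ring carbon gives the first matched comparison at this position, and in this assay it reads as a number 13 percentage points lower from compound 1 to compound 3 (beyond the scatter). This shows that growth inhibition at the tested concentration responds to the aryl group here, and in this pair the larger, methoxy-bearing aryl gives the lower number. The step belongs to the exchange as a whole, and no measurement on hand bears on what lies behind it.

Going by these compounds, whether one methoxy group alone would give the same step remains open, since compound 2 differs from compound 1 at more than one place and cannot settle it. Also open, on these data alone, is how a dimethylamino group or a carboxylic acid on this aryl ring would read in this assay.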